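The compounds below may be only part of what the source reports. "The series", "measured", "known", "first", "only" and "open" are said of these compounds alone.

Compound 1 `C=C(c1cc(OC)c(OC)c(OC)c1)c1ccc(OC)cc1NC(=O)CO` and compound 2 `C=C(c1ccc(OC)cc1NC(=O)CN)c1ccc(OC)c2c1OC(C)(C)C=C2` share a methylidene-linked aryl pair carrying an amide on one ring, and differ both in the other aryl part and in the amide chain. In a functional assay on MCF7 cells (Homo sapiens) for antiproliferative activity, read by MTT assay, with a stated time of 48 h (a higher number here means a weaker inhibitor, a lower number a stronger inhibitor), compound 1 gives 110 nM, and compound 2 gives 220 nM in this assay. Compound 1 has the lower of the two numbers, but the gap to compound 2 lies within the scatter, so the two compounds cannot be placed in order on these data.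

Compound 3 `C=C(c1cc(OC)c(OC)c(OC)c1)c1ccc(OC)cc1NC(=O)CNCC` keeps the whole of compound 1 apart from one change in the amide chain: ethylamino in place of hydroxy on a saturated chain carbon bound to a carbonyl carbon. For the measured compounds named here, no measured pair in the set isolates this particular change, so its effect has to be guessed. The nearest hint is compound 2, whose chain ends in a free amine and which gives 220 nM in this assay, close to compound 1. On that basis compound 3 is expected to sit near compound 1, with a step of a 1.4-fold higher number from compound 1 to compound 3 (0.13 log units; within the scatter) that stays within the scatter. Compound 3 is therefore estimated at 150 nM in this assay, with a range from 50 nM to 450 nM.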

Compound 3, half-maximal inhibitory concentration: 860 nM
Compound 3: the middle estimate sits 5.7-fold (0.76 log units) below what was measured, outside the stated range (above it).
By their numbers in this assay, from the lowest: compounds 1 and 2 (each within the scatter of the next); then compound 3.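

For the compounds shown here, this is the first step in the set that isolates a single place, and it shows that the saturated chain carbon bound to a carbonyl carbon does not tolerate every substituent equally: in this assay, ethylamino in place of hydroxy gives a 7.8-fold higher number from compound 1 to compound 3 (0.89 log units; beyond the scatter) on an otherwise unchanged core. Under HOW the two groups are counted, the hydrogen-bond donors, hydrogen-bond acceptors and net charge stay the same, while the heavy atoms go from 1 in hydroxy to 3 in ethylamino, so the step appears without any change in the donor, acceptor or charge counts. Nothing measured here explains the step.

The compounds shown leave open whether the higher number follows the nitrogen or the ethyl part of the new group, since compound 2 differs from compound 3 in more than one place and cannot settle this. A methylamino or dimethylamino group, or a methoxy group, on the same chain carbon of the core of compound 1 would help separate those two readings.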